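A few compounds are considered here, and "the series" means these few. Any claim that something is new, unique, unknown or untested is made for them only; others in the source may bear on it.

Compound 1 `Cc1ccsc1[C@@H]1C[C@H](O)Cc2cc(F)ccc2N1` is tolerated by the cells to a high degree: in an ADME assay on THP-1 cells (Homo sapiens) for cytotoxicity (a higher number here means that more compound is tolerated, a lower number that less compound is tolerated), compound 1 gives 1810000 nM. Compound 2 `Cc1ccsc1[C@@H]1C[C@H](O)Cc2cc(OC(F)(F)F)ccc2N1` differs from compound 1 in one spot, (trifluoromethoxy in place of fluoro on an aromatic carbon), and in this assay compound 2 gives 89700 nM, a step of a 20-fold lower number from compound 1 to compound 2 (1.30 log units; beyond the scatter). Compound 3 `O[C@@H]1Cc2cc(F)ccc2N[C@H](c2ccoc2)C1` keeps the fluoro of compound 1 but carries a different ring on the core, (furan-3-yl in place of 3-methylthiophen-2-yl on a saturated ring carbon), and in this assay compound 3 gives 689000 nM, a step of a 2.6-fold lower number from compound 1 to compound 3 (0.42 log units; beyond the scatter). Compound 4 `O[C@@H]1Cc2cc(OC(F)(F)F)ccc2N[C@H](c2ccoc2)C1` has not been measured; it stands to compound 3 as compound 2 stands to compound 1, (trifluoromethoxy in place of fluoro on an aromatic carbon), the same change at the same place. Since that change gave a 20-fold lower number from compound 1 to compound 2 (1.30 log units; beyond the scatter) on the core of compound 1, a step of about a 20-fold lower number from compound 3 to compound 4 (1.29 log units; beyond the scatter) is expected here too, the ring difference between the two cores being set aside. Compound 4 is therefore estimated to give 35000 nM in this assay, with a likely range from 12000 nM to 120000 nM.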

Compound 4, half-maximal cytotoxic concentration: 460000 nM
The estimate for compound 4 lay 13-fold (1.12 log units) below the measured number; measured number above the stated range.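

In this assay, trifluoromethoxy in place of fluoro gives a 1.5-fold lower number from compound 3 to compound 4 (0.18 log units; within the scatter), so on the core bearing furan-3-yl this change has no effect that can be told from the scatter, and it does not repeat the much larger step seen on the core of compound 1: the same change on two cores in this assay, a 20-fold lower number (1.30 log units; beyond the scatter) from compound 1 to compound 2 and a 1.5-fold lower number (0.18 log units; within the scatter) from compound 3 to compound 4, 13-fold (1.13 log units) apart, beyond the scatter of two such steps

Read the other way, the ring swap does not carry over either, since a 5.1-fold higher number from compound 2 to compound 4 (0.71 log units; beyond the scatter) runs opposite in direction to a 2.6-fold lower number from compound 1 to compound 3 (0.42 log units; beyond the scatter): the same change on two cores in this assay, a 2.6-fold lower number (0.42 log units; beyond the scatter) from compound 1 to compound 3 and a 5.1-fold higher number (0.71 log units; beyond the scatter) from compound 2 to compound 4, 13-fold (1.13 log units) apart, beyond the scatter of two such steps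

So in these four compounds the effect of each change depends on what sits at the other place, but a single pair of cores cannot show why this happens or which of the two steps is more typical of the series.

The compounds shown leave open how a different group on that aromatic carbon, such as chloro, a nitrile or an amine, would behave on these two cores. They also leave open whether a carboxylic acid or a longer chain there would show the same dependence on the ring.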